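This account rests on a few compounds, and the source may have more. Where it says the series, first, only, none or still open, it means among the compounds named here.

Compound 1 `CCn1cc(C(=O)Nc2ccccc2)c(=O)c2cc(F)c(N3CCNC(C)C3)c(F)c21` gives 7400 nM
Compound 2 `CCn1cc(C(=O)Nc2ccccc2O)c(=O)c2cc(F)c(N3CCNC(C)C3)c(F)c21` gives 7430 nM
Compound 3 `CCn1cc(C(=O)Nc2cc([N+](=O)[O-])ccc2F)c(=O)c2cc(F)c(N3CCNC(C)C3)c(F)c21` gives 6900 nM

In a functional assay on MDA-MB-231 cells (Homo sapiens) for cytotoxicity, read by MTT assay (a higher number here means a weaker inhibitor, a lower number a stronger inhibitor), compound 3 (6900 nM) stands level with compound 1 and compound 2 within the scatter. Compound 4 `CCn1cc(C(=O)Nc2ccc(OC(F)(F)F)cc2)c(=O)c2cc(F)c(N3CCNC(C)C3)c(F)c21` differs from compound 3 on an amide-type nitrogen (4-(trifluoromethoxy)phenyl in place of 2-fluoro-5-nitrophenyl on an amide-type nitrogen) with 4-(trifluoromethoxy)phenyl in place of 2-fluoro-5-nitrophenyl. Among the measured compounds shown here, no measured compound carries that group. The steps that swap the group on this nitrogen (a 1.1-fold lower number from compound 1 to compound 3 (0.03 log units; within the scatter) and a 1.1-fold lower number from compound 2 to compound 3 (0.03 log units; within the scatter)) lie within the scatter, as does the hydroxy step (a 1.0-fold higher number from compound 1 to compound 2 (0.00 log units; within the scatter)), so no step beyond the scatter is expected for compound 4 in either direction. The expected change is small (a 1.2-fold lower number from compound 3 to compound 4 (0.06 log units; within the scatter)). The estimate for compound 4 is 6000 nM (expected range 2800 nM to 12000 nM).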

Compound 4, half-maximal inhibitory concentration: 980 nM
Compound 4: middle estimate off by 6.1-fold (0.79 log units), on the high side; the measured number lies below the stated range.
By their numbers in this assay, from the lowest: compound 4; then compounds 3, 1 and 2 (each within the scatter of the next).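

In this assay the group on the amide-type nitrogen proves able to move the number, since 4-(trifluoromethoxy)phenyl gives a 7.0-fold lower number from compound 3 to compound 4 (0.85 log units; beyond the scatter) and a 7.6-fold lower number from compound 2 to compound 4 (0.88 log units; beyond the scatter) while the earlier swaps there stayed within the scatter. The added trifluoromethoxy group is the only difference behind a 7.6-fold lower number from compound 1 to compound 4 (0.88 log units; beyond the scatter) and so suffices for the change. No evidence on hand bears on the reason for this step.

The compounds shown leave open whether a methoxy or a trifluoromethyl group on the same phenyl would give a step of similar size. They also leave open whether a chlorine there would do the same.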